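A few compounds are considered here, and "the series" means these few. Any claim that something is new, unique, unknown or untested is made for them only; others in the source may bear on it.

In a functional assay on MGC-803 cells (Homo sapiens) for inhibition, read by CCK-8 assay, with a stated time of 48 h (on this read-out lower numbers stand for stronger inhibition and higher numbers for weaker inhibition), three compounds have been measured. Compound 1 `COc1ccc(CN(C(=O)CSC(=S)N2CCCC2)c2cc(OC)c(OC)c(OC)c2)cc1` reaches only a limit, > 20000 nM. Compound 2 `CCN1CCN(CC(=O)N(Cc2ccc(OC)cc2)c2cc(OC)c(OC)c(OC)c2)CC1` likewise reaches only a limit, > 20000 nM. Within the data shown here, compound 3 `COc1cc(N(Cc2ccc(Cl)cc2)C(=O)CSC(=S)N2CCN(C(=O)OC(C)(C)C)CC2)cc(OC)c1OC` gives 12900 nM, the only actual number of the three, and so the only firm starting point.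

Compound 4 `COc1ccc(CN(C(=O)CSC(=S)N2CCN(C(=O)OC(C)(C)C)CC2)c2cc(OC)c(OC)c(OC)c2)cc1N=[N+]=[N-]` differs from compound 3 at one place: 3-azido-4-methoxyphenyl in place of 4-chlorophenyl on a saturated chain carbon bound to an amide-type nitrogen. Put another way, 4-chlorobenzyl gives way to 3-azido-4-methoxybenzyl.

The measured data offer little guidance on this change. Among the measured compounds shown here, the one measured step, a step that the two limits leave unreadable from compound 1 to compound 2, cannot be sized, and it sits elsewhere, on a saturated chain carbon bound to a carbonyl carbon. Nothing measured therefore points in either direction, and the expectation rests on compound 3 at 12900 nM. Also relevant is the limit of > 20000 nM in this assay, at which 2 of the 3 values shown sit, so compound 4 may well return only a limit in this assay.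

No change beyond the usual scatter is expected, and the estimated step is a 1.1-fold lower number from compound 3 to compound 4 (0.03 log units; within the scatter). For compound 4 the estimated value is 12000 nM, with an expected range from 3500 nM to 20000 nM.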

Compound 4, half-maximal inhibitory concentration: 810 nM
Compound 4: the middle estimate sits 15-fold (1.17 log units) above what was measured; the whole stated range lies above it.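

In this assay, 3-azido-4-methoxybenzyl in place of 4-chlorobenzyl gives a 16-fold lower number from compound 3 to compound 4 (1.20 log units; beyond the scatter), so the group on the saturated chain carbon bound to an amide-type nitrogen is a place where a single change moves the read-out well beyond the scatter. Among these compounds, the earlier compounds could not show this, as the only step among them cannot be read and lies at a different place, on a saturated chain carbon bound to a carbonyl carbon. The step also gives the set its first comparison between two actual numbers, clear of the limit that holds the other values: the limit of > 20000 nM in this assay, at which 2 of the 4 values shown sit.

The change removes a chlorine and brings in an azido and a methoxy group at once, so the compounds shown do not tell which of these parts carries the step, and no line of the data gives a cause for it. From the compounds shown here alone, it also stays open whether the azido group itself is needed, as a 3-amino-4-methoxybenzyl group, with an amine in its place, or a 3-cyano-4-methoxybenzyl group, with a nitrile there, would be the direct test.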